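Methoxy on the aryl ring across two bicyclic ketone ethers

The source may hold more compounds than are shown below. What is called first, only, known or untested is meant among the compounds shown, and "the series" means these compounds.

Measured so far in a functional assay on MDA-MB-231 cells (Homo sapiens) for cytotoxicity, read by MTT assay, with a stated time of 48 h; a lower number here means a stronger inhibitor, a higher number a weaker inhibitor:
compound 1 `O=C1C[C@H](OCc2cn(Cc3ccccc3)nn2)[C@H]2CO[C@@H]1O2`, > 50000 nM
compound 2 `COc1ccc(Cn2cc(CO[C@H]3CC(=O)[C@@H]4OC[C@H]3O4)nn2)cc1`, 34800 nM
compound 3 `O=C1C[C@H](OCc2cc(-c3ccccc3)no2)[C@H]2CO[C@@H]1O2`, 21900 nM

In this assay compound 1 gives > 50000 nM, which is a limit of the assay and not a number (the limit of > 50000 nM in this assay, at which 1 of the 3 values shown sits). Compound 2 carries methoxy in place of hydrogen on an aromatic carbon and gives 34800 nM in this assay; the step is an at least 1.4-fold lower number from compound 1 to compound 2 (0.15 log units; that floor lies within the scatter). Compound 3 gives 21900 nM in this assay; the difference between its core and that of compound 1 is not broken down here. Compound 4 `COc1ccc(-c2cc(CO[C@H]3CC(=O)[C@@H]4OC[C@H]3O4)on2)cc1` applies the same change to compound 3, (methoxy in place of hydrogen on an aromatic carbon), with the place described in the same words. The step is expected to be a 1.5-fold lower number from compound 3 to compound 4 (0.16 log units; within the scatter), resting on the earlier step of an at least 1.4-fold lower number from compound 1 to compound 2 (0.15 log units; that floor lies within the scatter), whose floor alone is known. Compound 4 is therefore estimated at 15000 nM in this assay, between 7000 nM and 40000 nM.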

Compound 4, half-maximal inhibitory concentration: 21900 nM
Compound 4: the middle estimate sits 1.5-fold (0.16 log units) below what was measured; low and high end bracket the measured number.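

In this assay, phenyl to 4-methoxyphenyl on the core of compound 3 gives no change at the digits printed from compound 3 to compound 4 (within the scatter). These two cores neither confirm nor rule out that the change carries over from one to the other: the same change on two cores in this assay, an at least 1.4-fold lower number (0.15 log units; that floor lies within the scatter) from compound 1 to compound 2 and no change at the digits printed (within the scatter) from compound 3 to compound 4; the limit leaves it open whether they differ. On these data alone, compound 1 stands at a limit of the assay, not at a number, so the size of the first step remains unknown: the limit of > 50000 nM in this assay, at which 1 of the 4 values shown sits.

Still open, as far as these compounds go, is whether an amine or a carboxylic acid in place of the methoxy would move the number on either core. From the compounds shown here alone, a longer alkoxy chain at the same place is equally open.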